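The compounds below may be only part of what the source reports. "The series", "measured", "known", "first", "only" and "open" are said of these compounds alone.

Compound 3 `CC(C)(C)C1=NN(c2ccc(Cl)cc2)C(c2ccc(O)c(F)c2)C1` gives 98.5% in an assay on isolated protein for inhibition of protein kinase C zeta type (Homo sapiens), with a stated time of 4 min, tested at 62.5 uM (a lower number here means less inhibition, a higher number more inhibition at the concentration tested (going by the name of the read-out)), the highest of the three measured numbers. Compound 2 `CC(C)(C)C1=NN(c2ccccc2F)C(c2ccc(O)cc2)C1` gives 57.6% in this assay, and compound 1 `CC(C)(C)C1=NN(c2ccccc2Cl)C(c2ccc(O)cc2)C1` gives 57.1%. How the core of compound 3 differs from that of compound 2 is not broken down here. From compound 2 to compound 1 the change is chloro in place of fluoro on an aromatic carbon, and it made a number 0.5 percentage points lower from compound 2 to compound 1 (within the scatter). The same kind of change, (chloro in place of fluoro on an aromatic carbon), leads from compound 3 to compound 4 `CC(C)(C)C1=NN(c2ccc(Cl)cc2)C(c2ccc(O)c(Cl)c2)C1`, though here the place is ortho to a hydroxy group and meta to a large group rather than ortho to a large group. The expected step in this assay is a number 3.5 percentage points lower from compound 3 to compound 4 (within the scatter), resting on the earlier exchange, which gave a number 0.5 percentage points lower from compound 2 to compound 1 (within the scatter), and on compound 3 already standing at 98.5%. Compound 4 is therefore estimated at 95% in this assay, most likely between 80% and 100%.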

Compound 4, a percentage reported as inhibition, at one concentration (the size of the read-out at that concentration, not a potency): 94.5%
Compound 4: the middle estimate sits 0.5 percentage points above what was measured; the measured number falls inside the stated range.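

In this assay, chloro in place of fluoro gave a number 4 percentage points lower from compound 3 to compound 4 (within the scatter). Set beside the earlier exchange, the change carried over from one core to the other without a discernible difference: the same change on two cores in this assay, a number 0.5 percentage points lower (within the scatter) from compound 2 to compound 1 and a number 4 percentage points lower (within the scatter) from compound 3 to compound 4, 3.5 percentage points apart, within the scatter of two such steps. Going by these compounds alone, this rests on only two pairs of compounds, each read at one concentration, so it shows neither that the exchange would be equally silent on other cores nor that compound 3 and compound 4 match in potency.

The compounds shown leave open what a group other than a halogen, such as methyl or methoxy, would do at this place. They also leave open whether an amine or a carboxylic acid could stand in for the hydroxy group.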